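Removing the tert-butoxycarbonyl group from compound 2

A few compounds are considered here, and "the series" means these few. Any claim that something is new, unique, unknown or untested is made for them only; others in the source may bear on it.

In a functional assay on MDA-MB-231 cells (Homo sapiens) for inhibition, read by MTT assay, with a stated time of 72 h (a higher number here means a weaker inhibitor, a lower number a stronger inhibitor), compound 2 `CC(C)[C@H](NC(=O)c1cc(Cl)ccc1OCCNC(=O)OC(C)(C)C)C(=O)Nc1cc(C(F)(F)F)cc(C(F)(F)F)c1` gives > 10000 nM, which is a limit of the assay and not a number.

The next member to read is compound 3 `CC(C)[C@H](NC(=O)c1cc(Cl)ccc1OCCN)C(=O)Nc1cc(C(F)(F)F)cc(C(F)(F)F)c1`, still unmeasured. It differs from compound 2 by one change, hydrogen in place of tert-butoxycarbonyl on an amine nitrogen, which leaves a 2-aminoethyl group.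

Compound 1 `CC(C)[C@H](NC(=O)c1cc(Cl)ccc1OCCN)C(=O)Nc1cc(F)cc(C(F)(F)F)c1` also carries a 2-aminoethyl group, and in this assay compound 1 gives 4340 nM. Among the compounds with values here, that is the only true number so far.

Within the data shown here, no measured pair shows this change on its own, and the limit on one side leaves the true size of the step open. The expectation of a reading inside the range of this assay rests on compound 1 at 4340 nM.

The expected move is toward a stronger inhibitor, and the estimated step is an at least 2.8-fold lower number from compound 2 to compound 3 (0.45 log units; beyond the scatter). The size of that step is uncertain and may prove larger.

For compound 3 the estimate is 3500 nM, with an expected range of 1300 nM to 9000 nM.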

Compound 3, half-maximal inhibitory concentration: 5430 nM
For compound 3 the middle estimate is 1.6-fold (0.19 log units) below the measured one; measured number inside the range.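

In this assay compound 2 gives > 10000 nM as a limit of the assay and not a number. Within the data shown here, with the 2-aminoethyl group held fixed, trifluoromethyl in place of fluoro on an aromatic carbon gives a 1.3-fold higher number from compound 1 to compound 3 (0.10 log units; within the scatter) and so the two read alike, which is the first view of this exchange on the shared core. Hydrogen in place of tert-butoxycarbonyl on an amine nitrogen gives an at least 1.8-fold lower number from compound 2 to compound 3 (0.26 log units; that floor lies within the scatter) and the free 2-aminoethyl group now has a true number on this core, but the size of the step stays open because one side of it is a limit: the limit of > 10000 nM in this assay, at which 1 of the 3 values shown sits.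

Still open, from the compounds shown here alone, is whether an acetyl group on the same amine nitrogen would read like hydrogen or like tert-butoxycarbonyl, and whether a longer chain such as 3-aminopropyl would keep the reading of the 2-aminoethyl group. Also open, going by these compounds, is whether a nitrile or a chloro group on that aromatic carbon would read like fluoro and trifluoromethyl.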